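This account rests on a few compounds, and the source may have more. Where it says the series, first, only, none or still open, it means among the compounds named here.

Compound 1 `Nc1ccc(-c2cc(=O)c3c(N)c(F)cc(F)c3o2)cc1F` gives 25 nM
Compound 2 `Nc1ccc(-c2cc(=O)c3c(N)c(Cl)cc(Cl)c3o2)cc1` gives 610 nM
Compound 3 `Nc1ccc(-c2cc(=O)c3c(N)ccc(F)c3o2)cc1` gives 170 nM

Going by the values given here, all three numbers come from a functional assay on MCF7 cells (Homo sapiens) for inhibition, in the presence of a further agent that is not named here (on this read-out higher numbers stand for weaker inhibition and lower numbers for stronger inhibition), and are the only guide available here. Compound 2 at 610 nM has the highest number of the three, which makes it the weakest inhibitor in this small set. Compound 3 and compound 1 both lie lower, and both gaps are beyond the scatter.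

The next compound is compound 4 `Nc1ccc(-c2cc(=O)c3c(N)c(Cl)ccc3o2)cc1`, which has not yet been measured. In it, hydrogen takes the place of chloro on an aromatic carbon, para to an amino group and meta to a chloro group that stays: hydrogen in place of chloro on an aromatic carbon.

Among the compounds with values here, no measured pair isolates this change, so its size cannot be read directly from the data. The only hint is weak: compound 3 at 170 nM carries no chloro group and has a lower number than compound 2, although the two differ in more than one place. On that slim basis, the expected change is a 2.0-fold lower number from compound 2 to compound 4 (0.31 log units; beyond the scatter) in this assay, a modest move toward stronger inhibition that may not exceed the scatter. Compound 4 is estimated at 300 nM with an expected range from 70 nM to 1300 nM in this read-out.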

Compound 4, half-maximal inhibitory concentration: > 10000 nM
Compound 4 was reported as a limit (the forecaster's own chance of this, stated with the estimate: 10%); middle value at least 33-fold (1.52 log units) away from the limit.
By their numbers in this assay, from the lowest: compound 1; then compound 3; then compound 2. At a limit, above all of these: compound 4.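

Taking away this one chloro group, on the aromatic carbon para to an amino group, is the first change in the set that can be read on its own, and in this assay it gives an at least 16-fold higher number from compound 2 to compound 4 (1.21 log units; beyond the scatter), a large step toward weaker inhibition. Compound 4 is reported only as a limit: the limit of > 10000 nM in this assay, at which 1 of the 4 values shown sits. Compounds 1, 2 and 3 all carry a halogen on this carbon, so they could not show what a bare hydrogen there does, whereas this step shows that in the core of compound 2 the chloro group cannot simply be dropped without a heavy loss on this read-out.

As far as these compounds go, what remains open is whether the need is for a halogen in particular, or whether a methyl or methoxy group on this same carbon would serve as well as the chloro group does. Also open, from the compounds shown here alone, is whether hydrogen in place of chloro would cost as much in a compound that differs elsewhere on the core, such as one with a fluoro group on the other side of the amino group.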